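The compounds below may be only part of what the source reports. "The series", "measured", "known", "first", "only" and "open" are said of these compounds alone.

Compound 1 `COc1cc(-c2cc(/C=C/C(=O)c3ccc(Cl)c(Cl)c3)[nH]n2)cc(OC)c1OC` is measured in a functional assay on M14 cells (Homo sapiens) for cytotoxicity, read by sulforhodamine B assay, with a stated time of 48 h, tested at 100 uM (a higher number here means a weaker effect of the compound at the concentration tested, a lower number a stronger effect), where compound 1 gives 20%. That is the higher of the two numbers in hand: compound 2 `COc1ccc(-c2cc(/C=C/C(=O)c3ccc(N)cc3)[nH]n2)cc1OC` gives -90% in this assay, a gap beyond the usual scatter. Compound 3 `COc1ccc(C(=O)/C=C/c2cc(-c3cc(OC)c(OC)c(OC)c3)n[nH]2)cc1OC` has not been measured; it differs from compound 1 by 3,4-dimethoxyphenyl in place of 3,4-dichlorophenyl on a carbonyl carbon. For the measured compounds named here, no measured pair isolates such a change, so the direction is uncertain; a moderate downward step from compound 1 to compound 3 is expected, a number 20 percentage points lower from compound 1 to compound 3 (beyond the scatter). Compound 3 is estimated at 0%, within a range from -70% to 45%.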

Compound 3, a percentage reported as activity, at one concentration (the size of the read-out at that concentration, not a potency): -68%
Beside the measured number, compound 3's estimate is 68 percentage points above it, within the range that was stated.
By their numbers in this assay, from the lowest: compound 2; then compound 3; then compound 1.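

On the carbonyl carbon, 3,4-dimethoxyphenyl in place of 3,4-dichlorophenyl gives a number 88 percentage points lower from compound 1 to compound 3 (beyond the scatter) in this assay, a large step towards a stronger effect at the concentration tested. This pair shows that a change at this one place, with the rest of compound 1 kept, is enough to move the read-out beyond the scatter. Nothing available here accounts for the step. As far as these compounds go, it remains open whether a nitrile or a carboxylic acid on that phenyl ring would give a stronger or weaker effect, and whether a single methoxy would suffice.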